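From hydroxy to a pyrrolidinyl side chain

This account rests on a few compounds, and the source may have more. Where it says the series, first, only, none or still open, it means among the compounds named here.

Compound 3 `COc1cccc(OC)c1C(=O)Nc1c[nH]nc1C(=O)O` gives > 50000 nM in an ADME assay on MRC5 cells (Homo sapiens) for inhibition, with a stated time of 72 h (on this read-out lower numbers stand for an effect already at smaller amounts and higher numbers for an effect only at larger amounts of compound), and this value is a limit, not a number. Its place among the measured compounds is the limit of > 50000 nM in this assay, at which 1 of the 3 values shown sits.

Two amides of the shared core have numbers. In this assay compound 1 `COc1cccc(OC)c1C(=O)Nc1c[nH]nc1C(=O)N[C@H]1CC[C@H](OC)CC1` gives 31000 nM, and compound 2 `COc1cccc(OC)c1C(=O)Nc1c[nH]nc1C(=O)N[C@H]1CC[C@H](O)CC1` gives 34000 nM. Between these two the data show a 1.1-fold higher number from compound 1 to compound 2 (0.04 log units; within the scatter).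

Compound 4 `COc1cccc(OC)c1C(=O)Nc1c[nH]nc1C(=O)NCCN1CCCC1` changes the same carbonyl carbon of compound 3: (2-(pyrrolidin-1-yl)ethyl)amino in place of hydroxy on a carbonyl carbon. The closest evidence comes from two measured steps that replace an amine group on this carbon with hydroxy, the opposite direction to the present change. They are an at least 1.6-fold higher number from compound 1 to compound 3 (0.20 log units; that floor lies within the scatter) and an at least 1.4-fold higher number from compound 2 to compound 3 (0.16 log units; that floor lies within the scatter). Each gives only a minimum size, and neither minimum goes beyond the scatter. Going by the values given here, no measured compound carries the (2-(pyrrolidin-1-yl)ethyl)amino group, so its own contribution remains open.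

Compound 4 is therefore expected to resemble compound 1 at 31000 nM, with only a modest move towards a lower number. The expected change is an at least 1.6-fold lower number from compound 3 to compound 4 (0.22 log units; that floor lies within the scatter). The estimate for compound 4 is 30000 nM, with an expected range from 10000 nM to 50000 nM.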

Compound 4, half-maximal effective concentration: > 50000 nM
Compound 4 gave a limit, no number; the forecaster's own chance of this, stated with the estimate: 25%; middle value at least 1.6-fold (0.22 log units) away from the limit.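

In this assay compound 4 gives > 50000 nM, which is a limit and not a number, and it joins compound 3 there: the limit of > 50000 nM in this assay, at which 2 of the 4 values shown sit. This shows that an amide on this carbonyl carbon does not by itself bring a number within the range of the assay, since compound 1 and compound 2 have numbers while compound 4 has none. The data show an at least 1.4-fold higher number from compound 2 to compound 4 (0.16 log units; that floor lies within the scatter) and an at least 1.6-fold higher number from compound 1 to compound 4 (0.20 log units; that floor lies within the scatter), but each is only a minimum that stays within the scatter, so no real difference between the 2-(pyrrolidin-1-yl)ethyl group and either cyclohexyl group is established, and the step from hydroxy cannot be read with limits on both sides.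

As far as these compounds go, how far the true values of compound 3 and compound 4 lie past the limit remains open. From the compounds shown here alone, whether the pyrrolidin-1-yl ring or the ethyl chain matters at this position also remains open, and a dimethylamino group in place of the ring, or a longer chain in place of the ethyl, would be needed to separate the two.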